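The compounds below may be only part of what the source reports. "The series", "measured", "known", "first", "only" and "open" are said of these compounds alone.

Of the compounds shown here, three have so far been measured in a functional assay on the whole organism for inhibition, with Chlorella vulgaris as the target, read by spectrophotometry, with a stated time of 4 h; a lower number here means a stronger inhibitor, a higher number a weaker inhibitor. Compound 1 `CCCc1cnc(C(=O)/C=C/c2ccc(O)cc2)cn1` gives 514000 nM in this assay. Compound 2 `CC(C)c1cnc(C(=O)/C=C/c2ccccc2O)cn1` gives 78000 nM in this assay. Compound 3 `CCCCCCCCSc1cc(C(N)=S)ccn1` gives 48000 nM in this assay. Among these three numbers compound 2 stands second highest: its nearest neighbour is compound 3, whose number is lower by an amount within the scatter, while compound 1 lies furthest from it, with a higher number beyond the scatter. Compound 1 and compound 2 differ in more than one place, so their two values are simply set side by side, without a step between them.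

Compound 4 `CCCc1cnc(C(=O)/C=C/c2ccccc2O)cn1` has not yet been measured. It differs from compound 2 in one place: propyl in place of isopropyl on an aromatic carbon. Among the measured compounds shown here, no pair of measured compounds shows this change, so there is no measured step to lean on. For the measured compounds named here, the two structures hold the same atoms, joined differently, and with no comparable step the expected size of the move is a 1.3-fold higher number from compound 2 to compound 4 (0.11 log units; within the scatter), not beyond the scatter. Compound 4 is therefore estimated at 100000 nM in this assay, within a range from 40000 nM to 250000 nM.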

Compound 4, half-maximal inhibitory concentration: 100000 nM
Compound 4: middle estimate and measured number agree at the digits printed; measured number inside the range.
By their numbers in this assay, from the lowest: compounds 3, 2 and 4 (each within the scatter of the next, the first and the last beyond it); then compound 1.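

In this assay, among the compounds shown here, this is the first change in one place that can be read, and replacing isopropyl with propyl on this aromatic carbon, next to the ring nitrogen and para to a large group, gives a 1.3-fold higher number from compound 2 to compound 4 (0.11 log units; within the scatter). For the compounds shown here, at this position, then, the branched and the straight three-carbon groups cannot be told apart in this assay, a point that the earlier compounds, which offered no such step, could not settle. Nothing on hand bears on the reason for this result.

The compounds shown leave open whether a group of another kind at this position, such as a longer chain, an amine or a carboxylic acid, would also stay within the scatter. They also leave open whether the same swap would read alike on the core of compound 1.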